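Shortening the chain from compound 2 to compound 3

This account rests on a few compounds, and the source may have more. Where it says the series, first, only, none or still open, it means among the compounds named here.

Among the compounds with values here, in a functional assay on A549 cells (Homo sapiens) for antiproliferative activity, read by MTT assay, with a stated time of 72 h (on this read-out higher numbers stand for weaker inhibition and lower numbers for stronger inhibition), compound 1 `CCCCCCCCCCNC[C@@H]1OC[C@H](N)[C@@H]1O` gives 47800 nM, the only numerical value so far. Compound 2 `CCCCCCCCCNC[C@@H]1OC[C@H](N)[C@H]1O` gives > 128000 nM in this assay, and this is a limit of the assay, not a number. Within the data shown here, no single-site step connects these two compounds, so the series offers no measured step for calibration.

Compound 3 `CCCCCCCCNC[C@@H]1OC[C@H](N)[C@H]1O` differs from compound 2 at one place: hydrogen in place of methyl on a saturated chain carbon, eight bonds along the chain from an amine nitrogen. In words, this is hydrogen in place of methyl on a saturated chain carbon, eight bonds along the chain from an amine nitrogen. The same difference, cut further out, reads butyl to propyl.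

The expectation in this assay starts from compound 2, whose > 128000 nM is a limit. The expected change, a step that the limit leaves unreadable from compound 2 to compound 3, is estimated to lie within the scatter, with any drift towards weaker inhibition. For compound 3 the estimated value is 150000 nM, with an expected range from 70000 nM to 300000 nM. A reported limit rather than a number is the more likely outcome.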

Compound 3, half-maximal inhibitory concentration: 71800 nM
The estimate for compound 3 lay 2.1-fold (0.32 log units) above the measured number, and the stated range covers the measured number.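

At this position, the change to hydrogen in place of methyl on a saturated chain carbon, eight bonds along the chain from an amine nitrogen, can now be given a size in this assay: an at least 1.7-fold lower number from compound 2 to compound 3 (0.25 log units; that floor lies within the scatter). Compound 2 gives > 128000 nM, which is a limit of the assay and not a number. The step is therefore only a floor, so the series does not show whether this one-carbon shortening moves the read-out beyond the usual scatter, because one end of the step rests on a limit: the limit of > 128000 nM in this assay, at which 1 of the 3 values shown sits.

Still open, on these data alone, is how the read-out follows chain length on the core of compound 3, since a single step with a limit at one end gives no trend, and a shorter chain or a longer chain than those of compound 2 and compound 3 would be needed to give one. Also open, as far as these compounds go, is how a terminal hydroxyl or a terminal phenyl on the chain would read at this position, and whether either would give a number or a limit in this assay.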